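The source may report more compounds than this note shows. Statements on the series, on what has been measured and on what is new or still open speak of the compounds shown alone.

In a functional assay on the whole organism (strain NMRI) for inhibition, with Mus musculus as the target, in the formalin test, with a stated time of 30 min, at a dose of 30 umol/kg by the intraperitoneal route (a higher number here means more inhibition at the dose given (going by the name of the read-out), a lower number less inhibition), compound 1 `[O-][S+](c1ccccc1)c1ccccc1-c1n[nH]c(=S)o1` gives 86.1%, compound 2 `O=S(=O)(c1ccccc1)c1ccccc1-c1n[nH]c(=S)o1` gives 58% and compound 3 `Nc1nnc(-c2ccccc2Sc2ccccc2)o1` gives 63.7%. Compound 2 holds the lowest of these three numbers; its gap to compound 3 lies within the scatter, while its gap to compound 1 lies beyond it. Compound 4 `Nc1nnc(-c2ccccc2S(=O)(=O)c2ccccc2)o1` differs from compound 2 in one place: a group of 6 heavy atoms (2 carbon, 3 nitrogen, 1 oxygen; one five-membered aromatic ring with 3 hetero atoms) in place of a group of 6 heavy atoms (2 carbon, 2 nitrogen, 1 oxygen, 1 sulfur; one five-membered aromatic ring with 3 hetero atoms), on an aromatic carbon. Among the measured compounds shown here, no measured pair shows this exact exchange, and compound 3, which carries the entering group, differs from compound 2 elsewhere as well, so the data do not fix a direction. The step from compound 2 to compound 4 in this assay is expected to be small, a number 2 percentage points higher from compound 2 to compound 4 (within the scatter), not beyond the scatter. Compound 4 is estimated to reach 60%, between 40% and 80%.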

Compound 4, a percentage reported as inhibition, in the whole organism at one dose (the size of the read-out at that dose, not a potency): 68.3%
The estimate for compound 4 lay 8.3 percentage points below the measured number, and the stated range covers the measured number.
By their numbers in this assay, from the lowest: compounds 2, 3 and 4 (each within the scatter of the next, the first and the last beyond it); then compound 1.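

In this assay, placing 5-amino-1,3,4-oxadiazol-2-yl on the aromatic carbon in place of the departing ring, with the rest of the molecule unchanged, gives a number 10.3 percentage points higher from compound 2 to compound 4 (beyond the scatter). Among the compounds shown here, this is the first exchange at this position that can be read on its own, and it shows a modest gain at the single dose tested. Nothing measured here accounts for this step. Going by these compounds, whether the same exchange gives a similar step on the core of compound 1 stays open. Also open, on these data alone, is what a carboxylic acid or a simple amine on that aromatic carbon would give.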